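Ether chain variation at the aromatic oxygen

The source may report more compounds than this note shows. Statements on the series, on what has been measured and on what is new or still open speak of the compounds shown alone.

Measured so far:
compound 1 `CCC(C)COc1cccc2ccc(N)nc12`, 36 nM in an assay on cells with melanin-concentrating hormone receptor 1 (Homo sapiens) as the target, read by radioligand binding; a lower number here means a stronger inhibitor, a higher number a weaker inhibitor
compound 2 `CC(C)Oc1cccc2ccc(N)nc12`, 437 nM in this assay

Compound 2 holds the highest of the two numbers. Going by the values given here, the only measured step, a 12-fold higher number from compound 1 to compound 2 (1.08 log units; beyond the scatter), is large and concerns the same oxygen that compound 3 `CSCCOc1cccc2ccc(N)nc12` varies: 2-(methylsulfanyl)ethyl in place of isopropyl on an oxygen on an aromatic ring. Among the compounds with values here, since shortening the chain at this oxygen gave that large loss, a return to a longer chain is expected to recover part of it, though the sulfur-bearing chain has no measured precedent here. Compound 3 is therefore expected near 150 nM, between 40 nM and 500 nM. The expected step is a 2.9-fold lower number from compound 2 to compound 3 (0.46 log units; beyond the scatter).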

Compound 3, half-maximal inhibitory concentration: > 2000 nM
Compound 3: a limit, no number (the forecaster's own chance of this, stated with the estimate: 3%); at least 13-fold (1.12 log units) between middle value and limit.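

The ether oxygen's substituent affects the number in more than length: the longer 2-(methylsulfanyl)ethyl chain gives not a recovery but an at least 4.5-fold higher number from compound 2 to compound 3 (0.66 log units; beyond the scatter), and against the 2-methylbutyl chain the change is an at least 55-fold higher number from compound 1 to compound 3 (1.74 log units; beyond the scatter). A longer chain at this oxygen is therefore not enough on its own to keep the number low. Compound 3 stands as a limit, not a number: the limit of > 2000 nM in this assay, at which 1 of the 3 values shown sits.

From the compounds shown here alone, whether the loss follows the sulfur atom or the unbranched chain stays open. An unbranched n-butyl chain or a 2-methoxyethyl chain on the same oxygen would separate the two.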